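The compounds below may be only part of what the source reports. "The series", "measured", "known", "first", "only" and "open" are said of these compounds alone.

Of the compounds shown here, three built on one shared core have been measured in a functional assay on CRL2813 cells (Homo sapiens) for cytotoxicity, read by sulforhodamine B assay, with a stated time of 5 days; on this read-out lower numbers stand for stronger inhibition and higher numbers for weaker inhibition. Compound 1 `O=C(Nc1cccc(F)c1)N[C@H]1CC[C@H](Oc2ccc(F)cc2)CC1` gives 8300 nM, compound 2 `O=C(Nc1cccc(C(F)(F)F)c1)N[C@H]1CC[C@@H](Oc2ccc(F)cc2)CC1` gives 2600 nM, and compound 3 `O=C(Nc1ccccc1[N+](=O)[O-])N[C@H]1CC[C@H](Oc2ccc(F)cc2)CC1` gives 3500 nM. Compound 3 thus stands second highest of the three: its value and that of compound 2 lie within the scatter of each other, while its distance from compound 1 lies beyond it. Compound 4 `Cc1cccc(NC(=O)N[C@H]2CC[C@H](Oc3ccc(F)cc3)CC2)c1` is the next step from compound 3: 3-methylphenyl in place of 2-nitrophenyl on an amide-type nitrogen. Among the measured compounds shown here, only one measured step bears on this change, the one in which a 2-nitrophenyl replaced a 3-fluorophenyl and produced a 2.4-fold lower number from compound 1 to compound 3 (0.38 log units; beyond the scatter). Compound 4 carries a 3-methylphenyl, a group closer in kind to the 3-fluorophenyl of compound 1 than to the 2-nitrophenyl of compound 3, so the expectation is that this earlier gain is largely given back, with a modest rise expected in this assay, a 1.9-fold higher number from compound 3 to compound 4 (0.27 log units; within the scatter). Compound 4 is therefore estimated at 6500 nM, with a range from 2500 nM to 16000 nM.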

Compound 4, half-maximal inhibitory concentration: 14400 nM
Beside the measured number, compound 4's estimate is 2.2-fold (0.35 log units) below it, and the stated range covers the measured number.
By their numbers in this assay, from the lowest: compounds 2 and 3 (each within the scatter of the next); then compounds 1 and 4 (each within the scatter of the next).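

Putting 3-methylphenyl in place of 2-nitrophenyl on the amide-type nitrogen gives a 4.1-fold higher number from compound 3 to compound 4 (0.61 log units; beyond the scatter), so the lower number seen with 2-nitrophenyl now holds against two different groups, not just 3-fluorophenyl. Methyl in place of fluoro on the aromatic carbon gives a 1.7-fold higher number from compound 1 to compound 4 (0.24 log units; within the scatter), so these two groups cannot be told apart in this assay. Nothing measured here gives a reason for these differences.

On these data alone, whether the difference goes with the nitro group itself or with where it sits on the ring stays open, since 2-nitrophenyl differs from both other groups in both respects. A 3-nitrophenyl or a 2-methylphenyl group would separate these two possibilities, and how a 3-aminophenyl group would read is equally unknown.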